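From 2,3-dimethoxyphenyl to plain phenyl

The source may hold more compounds than are shown below. What is called first, only, known or untested is meant among the compounds shown, and "the series" means these compounds.

Measured in a functional assay on MCF7 cells (Homo sapiens) for cytotoxicity, read by MTT assay, with a stated time of 72 h; on this read-out higher numbers stand for weaker inhibition and lower numbers for stronger inhibition:
- compound 1 `O=C1C(=Cc2ccc(F)cc2)C(=O)N(c2ccc(Cl)cc2)N1c1ccc(Cl)cc1`: 31400 nM
- compound 2 `COc1cccc(C=C2C(=O)N(c3ccc(Cl)cc3)N(c3ccc(Cl)cc3)C2=O)c1OC`: 11900 nM

Of these two, compound 2 has the lower number, which means stronger inhibition. Compound 3 `O=C1C(=Cc2ccccc2)C(=O)N(c2ccc(Cl)cc2)N1c1ccc(Cl)cc1` differs from it in one place: phenyl in place of 2,3-dimethoxyphenyl on a double-bonded chain carbon bound to a double-bonded ring carbon. Among the compounds with values here, the one measured step bearing on this change is a 2.6-fold lower number from compound 1 to compound 2 (0.42 log units; beyond the scatter), which brought in the same 2,3-dimethoxyphenyl. Removing that group is therefore expected to give a modest move towards a higher number in this assay, although a single step is thin evidence. The expected change is a 2.0-fold higher number from compound 2 to compound 3 (0.30 log units; within the scatter). For compound 3 the estimated value is 24000 nM, with a range of 10000 nM to 55000 nM.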

Compound 3, half-maximal inhibitory concentration: 20200 nM
Beside the measured number, compound 3's estimate is 1.2-fold (0.07 log units) above it; low and high end bracket the measured number.
By their numbers in this assay, from the lowest: compounds 2, 3 and 1 (each within the scatter of the next, the first and the last beyond it).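

In this assay, phenyl in place of 2,3-dimethoxyphenyl gives a 1.7-fold higher number from compound 2 to compound 3 (0.23 log units; within the scatter), and hydrogen in place of fluoro on an aromatic carbon gives a 1.6-fold lower number from compound 1 to compound 3 (0.19 log units; within the scatter). Plain phenyl at this place therefore cannot be told apart from either substituted ring, although compound 1 and compound 2 do stand apart from each other beyond the scatter. No measurement shown here offers an explanation for these numbers. Still open, on these data alone, is whether an amine or a carboxylic acid on this aromatic ring would give a number clearly different from that of compound 3.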